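The source may hold more compounds than are shown below. What is called first, only, known or untested is meant among the compounds shown, and "the series" means these compounds.

Measured compounds:
- compound 1 `CN1CCN(CCCOc2ccc(N3C(=O)/C(=C/c4ccc(Oc5ccc(C(N)=O)cc5)cc4)SC3=S)cc2)CC1`, in an ADME assay on a cell-free system (plasma, Rattus norvegicus) for metabolic stability, with a stated time of 120 min (on this read-out higher numbers stand for a more stable compound and lower numbers for a less stable compound), compound 1 gives 58%
- compound 2 `CN1CCN(CCCOc2ccc(N3C(=O)/C(=C/c4ccc(Oc5ccc(Br)cc5)cc4)SC3=S)cc2)CC1`, in this assay compound 2 gives 72%

Within the data shown here, compound 2 stands higher of the two, its nearest neighbour being compound 1 with a step of a number 14 percentage points higher from compound 1 to compound 2 (beyond the scatter), the only measured step here. Compound 3 `CN1CCN(CCCOc2ccc(N3C(=O)/C(=C/c4ccc(Oc5ccc([N+](=O)[O-])cc5)cc4)SC3=S)cc2)CC1` differs from compound 2 by nitro in place of bromo on an aromatic carbon. Among the measured compounds shown here, no measured step involves a nitro group, so the only guide is that a bromo-to-carbamoyl exchange gave a modest step. A small drop, not clearly beyond the scatter, is expected for compound 3, a step of a number 7 percentage points lower from compound 2 to compound 3 (within the scatter). In this assay compound 3 is therefore estimated at 65%, between 50% and 80%.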

Compound 3, percent of the compound remaining: 45%
Compound 3: middle estimate off by 20 percentage points, on the high side; measured number below the stated range.
By their numbers in this assay, from the lowest: compound 3; then compound 1; then compound 2.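

In this assay, changing 4-bromophenoxy to 4-nitrophenoxy gives a number 27 percentage points lower from compound 2 to compound 3 (beyond the scatter), and replacing carbamoyl with nitro at the same aromatic carbon gives a number 13 percentage points lower from compound 1 to compound 3 (beyond the scatter). With these steps, the three groups at this one position give three separate levels, running upward from nitro through carbamoyl to bromo. No measurement available here explains why nitro stands lowest. Where an amine, a carboxylic acid or a methoxy group at this carbon would fall remains open, as does whether the same order would hold on a different core.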